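The source may hold more compounds than are shown below. What is called first, only, known or untested is meant among the compounds shown, and "the series" means these compounds.

Of the compounds shown here, three sharing one core have been measured in an assay on HEK293 cells for positive allosteric modulation of metabotropic glutamate receptor 5 (Homo sapiens), read by FLIPR, with a stated time of 1 h; a higher number here means that more compound is needed for the effect, a lower number that less compound is needed. Compound 1 `CCN1CCc2nc(C#Cc3ccccc3)sc2C1` carries an ethyl group on the ring amine nitrogen; in this assay compound 1 gives only a limit, > 10000 nM. Compound 2 `CC(=O)N1CCc2nc(C#Cc3ccccc3)sc2C1`, with acetyl in place of that ethyl, likewise gives only a limit, > 10000 nM. Within the data shown here, compound 3 `CC1CC1C(=O)N1CCc2nc(C#Cc3ccccc3)sc2C1` is the single compound with a number here, and in this assay compound 3 gives 9.4 nM. The step from compound 1 to compound 2 cannot be sized (a step that the two limits leave unreadable from compound 1 to compound 2) because both values sit at the limit of > 10000 nM in this assay, at which 2 of the 3 values shown sit. The other two steps are large: an at least 1000-fold lower number from compound 1 to compound 3 (3.02 log units; beyond the scatter) and an at least 1000-fold lower number from compound 2 to compound 3 (3.02 log units; beyond the scatter).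

Compound 4 `O=C(C1CCCC1)N1CCc2nc(C#Cc3ccccc3)sc2C1` differs from compound 3 in one place: cyclopentyl in place of 2-methylcyclopropyl on a carbonyl carbon. Among the measured compounds shown here, of the measured steps only the one from compound 2 to compound 3 touches this position, and it compares a methyl with a ring; no measured pair compares one ring with another on the carbonyl carbon. The expected step is therefore within the scatter or a small rise, a 2.1-fold higher number from compound 3 to compound 4 (0.33 log units; beyond the scatter). Compound 4 is expected to give about 20 nM in this assay, with a likely range from 5 nM to 120 nM.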

Compound 4, half-maximal effective concentration: 19 nM
Estimate against measurement, compound 4: 1.1-fold (0.02 log units) above; the range from low to high includes it.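

Among these compounds, the step of a 2.0-fold higher number from compound 3 to compound 4 (0.31 log units; beyond the scatter) in this assay is the first comparison of one ring with another on the carbonyl carbon, and it is a modest one. The activity at this position therefore does not depend on 2-methylcyclopropyl alone, since cyclopentyl also gives an at least 520-fold lower number from compound 2 to compound 4 (2.72 log units; beyond the scatter) and an at least 520-fold lower number from compound 1 to compound 4 (2.72 log units; beyond the scatter). Both of those large steps start from a limit rather than a number: the limit of > 10000 nM in this assay, at which 2 of the 4 values shown sit.

Whether a ring is needed at all on the carbonyl carbon stays open, as the compounds shown hold no branched chain such as isopropyl there. How far ring size and substitution matter is also open, with plain cyclopropyl, cyclobutyl, cyclohexyl and rings holding an oxygen, such as tetrahydropyranyl, absent from the compounds shown.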